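From benzyl to (3-nitrophenyl)carbonyl on a shared core

A few compounds are considered here, and "the series" means these few. Any claim that something is new, unique, unknown or untested is made for them only; others in the source may bear on it.

Compound 1 `CC1=CC[C@H]2[C@H](CC[C@]2(C)O)C(C)(C)[C@@H]1CC[C@H]1[C@]2(C)CC[C@H](OC(=O)c3ccncc3)C(C)(C)O[C@H]2CC[C@@]1(C)O` gives 18000 nM
Compound 2 `CC1=CC[C@H]2[C@H](CC[C@]2(C)O)C(C)(C)[C@@H]1CC[C@H]1[C@]2(C)CC[C@H](OCc3ccccc3)C(C)(C)O[C@H]2CC[C@@]1(C)O` gives 29100 nM
Compound 3 `CC1=CC[C@H]2[C@H](CC[C@]2(C)O)C(C)(C)[C@@H]1CC[C@H]1[C@]2(C)CC/C(=N/OC(=O)c3ccccc3)C(C)(C)O[C@H]2CC[C@@]1(C)O` gives 27400 nM

All three values come from a functional assay on MDA-MB-231 cells (Homo sapiens) for antiproliferative activity, read by MTT assay, with a stated time of 72 h (on this read-out higher numbers stand for weaker inhibition and lower numbers for stronger inhibition), and compound 2 lies within the usual scatter of both other compounds, so the three cannot be ranked. Compound 4 `CC1=CC[C@H]2[C@H](CC[C@]2(C)O)C(C)(C)[C@@H]1CC[C@H]1[C@]2(C)CC[C@H](OC(=O)c3cccc([N+](=O)[O-])c3)C(C)(C)O[C@H]2CC[C@@]1(C)O` keeps the shared core but changes one group ((3-nitrophenyl)carbonyl in place of benzyl on an oxygen on a saturated carbon), with (3-nitrophenyl)carbonyl in place of benzyl on an oxygen on a saturated carbon. Compound 1 carries (pyridin-4-yl)carbonyl at that place, and its measured step to benzyl (a 1.6-fold higher number from compound 1 to compound 2 (0.21 log units; within the scatter)) stays within the scatter. For the measured compounds named here, no measured compound carries the new group, so the range stays wide. The expected step (a 1.5-fold lower number from compound 2 to compound 4 (0.16 log units; within the scatter)) is therefore none beyond the scatter. Compound 4 is estimated at 20000 nM (expected range 9000 nM to 40000 nM).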

Compound 4, half-maximal inhibitory concentration: 34700 nM
Estimate against measurement, compound 4: 1.7-fold (0.24 log units) below; measured number inside the range.
By their numbers in this assay, from the lowest: compounds 1, 3, 2 and 4 (each within the scatter of the next).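

Placing (3-nitrophenyl)carbonyl on this oxygen instead of benzyl gives a 1.2-fold higher number from compound 2 to compound 4 (0.08 log units; within the scatter) in this assay and so does not separate the two compounds. Among the two carbonyl-linked groups, 3-nitrophenyl in place of pyridin-4-yl gives a 1.9-fold higher number from compound 1 to compound 4 (0.29 log units; within the scatter) and so does not separate these compounds either. No available evidence bears on this result.

As far as these compounds go, whether any group on this oxygen can move the number beyond the scatter stays open. An amine or a carboxylic acid on the aromatic ring, or a longer chain in place of benzyl, would test this.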